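The source may report more compounds than this note shows. Statements on the series, on what has been measured and on what is new or still open speak of the compounds shown alone.

Among the measured compounds shown here, in a functional assay on DU-145 cells (Homo sapiens) for inhibition, read by trypan blue exclusion, with a stated time of 96 h (a lower number here means a stronger inhibitor of growth, a higher number a weaker inhibitor of growth), the measured compounds so far read as follows.

- Compound 1 `COc1ccc(/C=C(/Sc2ccc(C)cc2)C(=O)c2ccc(Br)cc2)cc1` gives 50000 nM
- Compound 2 `COc1ccc(/C=C(/SCc2ccc(Cl)cc2)C(=O)c2ccc(Br)cc2)cc1` gives 10000 nM
- Compound 3 `COc1ccc(/C=C(/SCc2ccc(F)cc2)C(=O)c2ccc(Br)cc2)cc1` gives 50000 nM

Compound 3 stands level with compound 1, and together they hold the highest of the three numbers. Compound 2 is the only one apart from them, with a 5.0-fold higher number from compound 2 to compound 3 (0.70 log units; beyond the scatter) as the measured step. Compound 4 `O=C(/C(=C\c1ccc(O)cc1)SCc1ccc(F)cc1)c1ccc(Br)cc1` is the next to be read. Its difference from compound 3 is hydrogen in place of methyl on an oxygen on an aromatic ring and amounts to methoxy to hydroxy, so 4-methoxyphenyl becomes 4-hydroxyphenyl.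

For the measured compounds named here, none of the measured steps touches that oxygen. They are a 5.0-fold lower number from compound 1 to compound 2 (0.70 log units; beyond the scatter) and no change at the digits printed from compound 1 to compound 3 (within the scatter) on the sulfur, along with the halogen step already given. They therefore offer no direction for this change. The modest size of a 5.0-fold higher number from compound 2 to compound 3 (0.70 log units; beyond the scatter) serves only to set the width of the range. The expected step is a 1.7-fold lower number from compound 3 to compound 4 (0.22 log units; within the scatter) and so none beyond the scatter is expected. In this assay the estimate for compound 4 is 30000 nM with an expected range from 8000 nM to 100000 nM.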

Compound 4, concentration for 50% growth inhibition: 10000 nM
Compound 4: the middle estimate sits 3.0-fold (0.48 log units) above what was measured; measured number inside the range.
By their numbers in this assay, from the lowest: compounds 2 and 4 (each within the scatter of the next); then compounds 1 and 3 (each within the scatter of the next).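

In this assay, among the compounds shown here, replacing 4-methoxyphenyl with 4-hydroxyphenyl gives a 5.0-fold lower number from compound 3 to compound 4 (0.70 log units; beyond the scatter), which shows that the number responds to a change on this oxygen, a place that none of the earlier steps touched. Removing the methyl here goes with stronger inhibition of growth, a reading that rests on this single pair, with 4-fluorobenzyl on the sulfur. Nothing available here explains the step.

On these data alone, it remains open whether the same change would have a similar effect with the 4-chlorobenzyl group of compound 2 on the sulfur. As far as these compounds go, how other groups at this place would read, such as ethoxy, an amine or a carboxylic acid, also remains open.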